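This account rests on a few compounds, and the source may have more. Where it says the series, first, only, none or still open, it means among the compounds named here.

Measured so far:
- compound 1 `CC1=C(C(=O)O[C@@H](C)CO[N+](=O)[O-])[C@H](c2cccc3nonc23)C([N+](=O)[O-])=C(C)C1` — 156 nM
- compound 2 `CC1=C(C(=O)OCC(C)O[N+](=O)[O-])C(c2cccc3nonc23)C([N+](=O)[O-])=C(C)C1` — 972 nM
- compound 3 `CC1=C(C(=O)O[C@@H](C)CO[N+](=O)[O-])[C@@H](c2cccc3nonc23)C([N+](=O)[O-])=C(C)C1` — 33700 nM

Read-out throughout is a functional assay (cardiac atrium) for agonist activity, with Cavia porcellus as the target; on this read-out lower numbers stand for an effect already at smaller amounts and higher numbers for an effect only at larger amounts of compound. On the three numbers compound 2 stands second highest: compound 1 sits at a lower number and compound 3 at a higher one, both differences beyond the scatter. Among the measured compounds shown here, the only single-place step measured is a 220-fold higher number from compound 1 to compound 3 (2.33 log units; beyond the scatter), which rests on the fact that compounds 1 and 3 differ only in the configuration as drawn alone and says nothing about the side chain.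

Compound 4 `CC1=C(C(=O)OCCO[N+](=O)[O-])C(c2cccc3nonc23)C([N+](=O)[O-])=C(C)C1` is compound 2 with this change: hydrogen in place of methyl on a saturated chain carbon bound to an oxygen on an unsaturated carbon and a saturated chain carbon. For the measured compounds named here, no measured step bears on that exchange, so no shift beyond the scatter is expected in this assay; the expected step is a 1.2-fold lower number from compound 2 to compound 4 (0.08 log units; within the scatter), carrying wide uncertainty. Compound 4 is estimated at 800 nM, within 200 nM to 3000 nM.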

Compound 4, half-maximal effective concentration: 31100 nM
Compound 4: the middle estimate sits 39-fold (1.59 log units) below what was measured; measured number above the stated range.
By their numbers in this assay, from the lowest: compound 1; then compound 2; then compounds 4 and 3 (each within the scatter of the next).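

In this assay, the exchange of 1-(nitrooxy)ethyl for (nitrooxy)methyl gives a 32-fold higher number from compound 2 to compound 4 (1.51 log units; beyond the scatter), so the methyl on this saturated chain carbon is not a silent substituent. The earlier large step came from configuration alone; this one shows that a single change in the side chain can also move the number far. Nothing at hand gives a cause for this step.

Open, on these data alone, is whether a longer chain at this carbon, such as 1-(nitrooxy)propyl, keeps the lower number, and whether an amine can stand in place of the nitrooxy group.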